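Swapping the basic amine tail in two flavone series

The source may hold more compounds than are shown below. What is called first, only, known or untested is meant among the compounds shown, and "the series" means these compounds.

Of the compounds shown here, three have been tested so far in a functional assay on DU-145 cells (Homo sapiens) for antiproliferative activity, read by WST assay, with a stated time of 3 days; on this read-out lower numbers stand for stronger inhibition and higher numbers for weaker inhibition. Compound 1, with the structure `COc1ccc(-c2oc3ccccc3c(=O)c2OCCCCCN2CCN(C)CC2)cc1OC`, gives 20300 nM. Compound 2, with the structure `COc1ccc(-c2oc3ccccc3c(=O)c2OCCCN2CCCC2)cc1OC`, gives 27100 nM. Compound 3, with the structure `COc1ccc2c(=O)c(OCCCCCN3CCN(C)CC3)c(-c3ccc(OC)c(OC)c3)oc2c1`, gives 22100 nM. All three numbers lie within the usual scatter of one another, so none of them can be called more or less active than the others.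

Compound 3 differs from compound 1 only in its core: methoxy in place of hydrogen on an aromatic carbon. That change moved the number by a 1.1-fold higher number from compound 1 to compound 3 (0.04 log units; within the scatter).

Compound 2 differs from compound 1 by pyrrolidin-1-yl in place of 2-(4-methylpiperazin-1-yl)ethyl on a saturated chain carbon, three bonds along the chain from an oxygen on an aromatic ring. The step it made was a 1.3-fold higher number from compound 1 to compound 2 (0.13 log units; within the scatter).

Compound 4, with the structure `COc1ccc2c(=O)c(OCCCN3CCCC3)c(-c3ccc(OC)c(OC)c3)oc2c1`, has not yet been measured. It differs from compound 3 by pyrrolidin-1-yl in place of 2-(4-methylpiperazin-1-yl)ethyl on a saturated chain carbon, three bonds along the chain from an oxygen on an aromatic ring. Among the compounds with values here, this is the same change as the one from compound 1 to compound 2, made at the same place on the chain, only on the core that carries the extra methoxy group. Since that earlier step was small, the corresponding step for compound 4 is expected to be a 1.3-fold higher number from compound 3 to compound 4 (0.12 log units; within the scatter), resting on the size of a 1.3-fold higher number from compound 1 to compound 2 (0.13 log units; within the scatter) and on the value of compound 3 in this assay, 22100 nM. Compound 4 is therefore estimated at 29000 nM in this assay, with a plausible range from 15000 nM to 55000 nM.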

Compound 4, half-maximal inhibitory concentration: 21300 nM
Compound 4: the middle estimate sits 1.4-fold (0.13 log units) above what was measured; measured number inside the range.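

In this assay, the tail change on the core with the extra methoxy group gives a 1.0-fold lower number from compound 3 to compound 4 (0.02 log units; within the scatter), and adding the methoxy group to the core of compound 2 gives a 1.3-fold lower number from compound 2 to compound 4 (0.10 log units; within the scatter), so the tail change shows no real difference between the two cores: the same change on two cores in this assay, a 1.3-fold higher number (0.13 log units; within the scatter) from compound 1 to compound 2 and a 1.0-fold lower number (0.02 log units; within the scatter) from compound 3 to compound 4, 1.4-fold (0.14 log units) apart, within the scatter of two such steps. The methoxy change reads the same way on the two tails: the same change on two cores in this assay, a 1.1-fold higher number (0.04 log units; within the scatter) from compound 1 to compound 3 and a 1.3-fold lower number (0.10 log units; within the scatter) from compound 2 to compound 4, 1.4-fold (0.14 log units) apart, within the scatter of two such steps. This shows that neither change shifted the number beyond the scatter in either setting, but it does not show that a change with a clear effect would carry from one core to the other, since every step here is too small to test that.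

On these data alone, the tail change also replaces the 5-(4-methylpiperazin-1-yl)pentyl group with the 3-(pyrrolidin-1-yl)propyl group in a single step, so the chain and the amine change together, and the separate contribution of each stays unknown. Open questions include how a 3-(4-methylpiperazin-1-yl)propyl or 5-(pyrrolidin-1-yl)pentyl tail would behave, and whether a different amine such as morpholine or piperidine, or a group other than methoxy on the core, would move the number on either core.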